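This account rests on a few compounds, and the source may have more. Where it says the series, first, only, none or still open, it means among the compounds named here.

Measured so far:
compound 1, `O=C(c1ccc(Cl)cc1)N1CC(c2nc(-c3cccc(F)c3)no2)C1` — 2500 nM
compound 2, `Cc1cccc(-c2noc(C3CN(C(=O)C4CCC(C(F)(F)F)CC4)C3)n2)c1` — 1000 nM
compound 3, `Cc1ccc(C(=O)N2CC(c3nc(-c4cccc(F)c4)no3)C2)cc1` — 6800 nM

Of the compounds shown here, three have been measured in an assay on HEK293 cells for positive allosteric modulation of metabotropic glutamate receptor 5 (Homo sapiens), read by FLIPR; on this read-out lower numbers stand for an effect already at smaller amounts and higher numbers for an effect only at larger amounts of compound. Compound 3 gives 6800 nM, and compound 1 gives 2500 nM. The two share a core and differ in one place: chloro in place of methyl on an aromatic carbon. That step made a 2.7-fold lower number from compound 3 to compound 1 (0.43 log units; beyond the scatter). Compound 2, which gives 1000 nM, stands at the lowest number of the three, and how its core differs from that of compound 3 is not broken down here.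

Compound 4, `O=C(C1CCC(C(F)(F)F)CC1)N1CC(c2nc(-c3cccc(Cl)c3)no2)C1`, has not yet been measured. It differs from compound 2 in one place: chloro in place of methyl on an aromatic carbon. Going by the values given here, this is the same kind of change as the one from compound 3 to compound 1, but not the same: there the chloro enters para to a large group, here it enters meta to a large group. Among the compounds with values here, the one measured step of this kind points to a lower number after the exchange. On that basis compound 4 is expected to show a step of about a 2.0-fold lower number from compound 2 to compound 4 (0.30 log units; within the scatter), a step of similar direction but with room for the different surroundings to shift its size. Compound 4 is therefore estimated at 500 nM in this assay, with a plausible range from 200 nM to 1500 nM.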

Compound 4, half-maximal effective concentration: 1000 nM
For compound 4 the middle estimate is 2.0-fold (0.30 log units) below the measured one; the measured number falls inside the stated range.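

Replacing methyl with chloro, which here turns 3-methylphenyl into 3-chlorophenyl, meta to a large group, gave no change at the digits printed from compound 2 to compound 4 (within the scatter) in this assay, so the lower number seen on the other core did not carry over to this one. The size of this exchange therefore cannot be treated as a fixed increment that transfers unchanged between the two cores shown, as the two steps, set side by side, make clear: the same change on two cores in this assay, a 2.7-fold lower number (0.43 log units; beyond the scatter) from compound 3 to compound 1 and no change at the digits printed (within the scatter) from compound 2 to compound 4, 2.7-fold (0.43 log units) apart, beyond the scatter of two such steps What this does not show is which difference between the two pairs matters, since they differ both in the surrounding core and in where on the molecule the exchange takes place, and a single pair on each core cannot separate those two, nor can it say whether either step would hold for other compounds in the series.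

From the compounds shown here alone, it remains open whether a methoxy group or a nitrile in the place of the chloro on the 3-chlorophenyl group would move the number on either core. Also open, going by these compounds, is how the reading would respond if the trifluoromethyl group shared by compound 2 and compound 4 gave way to an ethyl chain or a carboxylic acid.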